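Chain homologation in a chloroalkanamide sulfonate ester series

A few compounds are considered here, and "the series" means these few. Any claim that something is new, unique, unknown or untested is made for them only; others in the source may bear on it.

Compound 1 `O=C(CCl)Nc1ccc(S(=O)(=O)Oc2ccccc2I)cc1` carries a chloromethyl carbonyl amide on the shared core; in a functional assay on MCF7 cells (Homo sapiens) for antiproliferative activity, read by sulforhodamine B assay, with a stated time of 48 h (on this read-out higher numbers stand for weaker inhibition and lower numbers for stronger inhibition), compound 1 gives 2500 nM. Compound 3 `O=C(CCCl)Nc1ccc(S(=O)(=O)Oc2ccccc2I)cc1` differs from compound 1 only in the chain: chloromethyl in place of chloro on a saturated chain carbon bound to a carbonyl carbon. This change produced a 3.6-fold higher number from compound 1 to compound 3 (0.55 log units; beyond the scatter), so in this assay compound 3 gives 8900 nM.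

Compound 2 `CC(C)c1ccccc1OS(=O)(=O)c1ccc(NC(=O)CCCl)cc1` shares the longer chain of compound 3 but a different core; the difference between the two cores is not broken down here. In this assay compound 2 gives 9000 nM, and the step of a 1.0-fold lower number from compound 2 to compound 3 (0.00 log units; within the scatter) shows the two cores giving numbers that cannot be told apart.

Compound 4 `CC(C)c1ccccc1OS(=O)(=O)c1ccc(NC(=O)CCCCl)cc1` extends the chain of compound 2 once more: chloromethyl in place of chloro on a saturated chain carbon, two bonds along the chain from a carbonyl carbon. This is the same kind of change as that from compound 1 to compound 3, not the same: there the new carbon entered on a saturated chain carbon bound to a carbonyl carbon, here on a saturated chain carbon two bonds along the chain from a carbonyl carbon. Within the data shown here, the one measured instance of the change gave a weaker number, a 3.6-fold higher number from compound 1 to compound 3 (0.55 log units; beyond the scatter), and the two cores look interchangeable on the strength of a 1.0-fold lower number from compound 2 to compound 3 (0.00 log units; within the scatter). Among the measured compounds shown here, compound 4 is therefore expected to be weaker than compound 2 by a 2.0-fold higher number from compound 2 to compound 4 (0.30 log units; within the scatter) in this assay, with the size uncertain since only one instance and a different place support it. Compound 4 is estimated at 18000 nM, most likely between 7000 nM and 45000 nM.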

Compound 4, half-maximal inhibitory concentration: 5200 nM
Compound 4: the middle estimate sits 3.5-fold (0.54 log units) above what was measured; measured number below the stated range.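

Chain extension does not carry over as one fixed step between these cores in this assay. On the core of compound 2, the step is a 1.7-fold lower number from compound 2 to compound 4 (0.24 log units; within the scatter), so the added carbon leaves no readable difference there, and the comparison with the earlier instance reads: the same change on two cores in this assay, a 3.6-fold higher number (0.55 log units; beyond the scatter) from compound 1 to compound 3 and a 1.7-fold lower number (0.24 log units; within the scatter) from compound 2 to compound 4, 6.2-fold (0.79 log units) apart, beyond the scatter of two such steps

Among these compounds, this does not show that the core alone sets the outcome: the two instances differ in place as well as in core, one falling on a saturated chain carbon bound to a carbonyl carbon and the other on a saturated chain carbon two bonds along the chain from a carbonyl carbon, and there is only one instance of each, so core and chain place cannot be separated.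

The (3-chloropropyl)carbonyl chain on the core of compound 1 and the chloromethyl carbonyl group on the core of compound 2 would complete the comparison on each core, and the compounds shown leave both open. Also open, going by these compounds, is what happens with a chain longer than the (3-chloropropyl)carbonyl chain, or with an amine or a hydroxyl group in place of the chlorine at the chain end.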